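Changing one group on a shared core

A few compounds are considered here, and "the series" means these few. Any claim that something is new, unique, unknown or untested is made for them only; others in the source may bear on it.

Compound 1 `COc1cc(-c2ccnc3cc(-c4ccccc4)nn23)cc(OC)c1OC`: 254 nM
Compound 2 `COc1cc(-c2ccnc3cc(-c4ccc5cc[nH]c5c4)nn23)cc(OC)c1OC`: 23 nM
Compound 3 `COc1cc(-c2ccnc3cc(-c4ccc5cnn(C)c5c4)nn23)cc(OC)c1OC`: 279 nM

In a functional assay on MCF7 cells (Homo sapiens) for inhibition, read by CCK-8 assay, with a stated time of 48 h (a lower number here means a stronger inhibitor, a higher number a weaker inhibitor), compound 3 stands level with compound 1, as a 1.1-fold higher number from compound 1 to compound 3 (0.04 log units; within the scatter) shows. Compound 2 lies far lower, with a 12-fold higher number from compound 2 to compound 3 (1.08 log units; beyond the scatter).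

Compound 4 `COc1ccc(-c2cc3nccc(-c4cc(OC)c(OC)c(OC)c4)n3n2)cc1F` carries 3-fluoro-4-methoxyphenyl in place of 1-methyl-1H-indazol-6-yl on an aromatic carbon.

The same carbon changed in the measured steps, and an 11-fold lower number from compound 1 to compound 2 (1.04 log units; beyond the scatter) shows that a swap there can matter greatly. Within the data shown here, no measured compound carries a substituted phenyl, so the direction remains uncertain. A moderate step is expected, a 3.1-fold lower number from compound 3 to compound 4 (0.49 log units; beyond the scatter). The estimate for compound 4 is 90 nM, within an expected range of 20 nM to 400 nM.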

Compound 4, half-maximal inhibitory concentration: 183 nM
Compound 4: the middle estimate sits 2.0-fold (0.31 log units) below what was measured, and the stated range covers the measured number.
By their numbers in this assay, from the lowest: compound 2; then compounds 4, 1 and 3 (each within the scatter of the next).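

In this assay, putting 3-fluoro-4-methoxyphenyl on this carbon gives no change that stands clear of the scatter, either against plain phenyl (a 1.4-fold lower number from compound 1 to compound 4 (0.14 log units; within the scatter)) or against 1-methyl-1H-indazol-6-yl (a 1.5-fold lower number from compound 3 to compound 4 (0.18 log units; within the scatter)). Among these four groups, only 1H-indol-6-yl stands apart (an 8.0-fold higher number from compound 2 to compound 4 (0.90 log units; beyond the scatter)), so adding these two substituents to the phenyl does not match it. Nothing available explains this result.

Compounds 2 and 3 differ in both the ring nitrogen and the methyl group, so 1H-indazol-6-yl and 1-methyl-1H-indol-6-yl would be needed to separate these two changes. As far as these compounds go, it also remains open how a phenyl carrying only fluorine, only methoxy or an amine would behave here.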